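Swapping the Aryl on the Pyrazole Nitrogen for Methyl

The compounds below may be only part of what the source reports. "The series", "measured", "known", "first", "only" and "open" are said of these compounds alone.

Of the compounds shown here, two sharing one core have been measured in an assay for displacement of a labelled ligand from Sigma non-opioid intracellular receptor 1 (Cavia porcellus), read by scintillation counting, with a stated time of 180 min; a lower number here means a stronger inhibitor, a higher number a weaker inhibitor. Compound 1 `c1ccc(CN2CCC3(CC2)OCCc2c3cnn2-c2ccccc2)cc1` gives 1.71 nM, and compound 2 `CC(C)CCN1CCC2(CC1)OCCc1c2cnn1-c1ccccc1` gives 0.98 nM. For the measured compounds named here, the only measured step, a 1.7-fold lower number from compound 1 to compound 2 (0.24 log units; within the scatter), touches the chain on the amine nitrogen, not the aromatic nitrogen. Compound 2 holds the lowest of the two numbers, yet its gap to compound 1 is within the scatter, so neither can be called stronger.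

Compound 3 `CC(C)CCN1CCC2(CC1)OCCc1c2cnn1C` differs from compound 2 by methyl in place of phenyl on an aromatic nitrogen. Going by the values given here, no measured step bears on this place, so the change is untested here; a modest weakening is guessed, with wide uncertainty. The step this expectation means is a 5.1-fold higher number from compound 2 to compound 3 (0.71 log units; beyond the scatter). For compound 3 the estimated value in this assay is 5 nM, within a range from 1 nM to 30 nM.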

Compound 3, inhibition constant: 30 nM
Beside the measured number, compound 3's estimate is 6.0-fold (0.78 log units) below it; the measured number falls inside the stated range.
By their numbers in this assay, from the lowest: compounds 2 and 1 (each within the scatter of the next); then compound 3.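

In this assay, the group on the aromatic nitrogen now has a measured effect: methyl in place of phenyl gives a 31-fold higher number from compound 2 to compound 3 (1.49 log units; beyond the scatter). The earlier step, on the chain at the amine nitrogen, gave a 1.7-fold lower number from compound 1 to compound 2 (0.24 log units; within the scatter), so this is the first change shown that clearly separates two compounds. This is one pair of compounds, so it shows that this swap weakens binding with the chain of compound 2 in place, and nothing available explains why the number rises.

From the compounds shown here alone, it remains open whether a group such as ethyl, cyclohexyl or pyridyl on this nitrogen would give a number close to that of compound 2 or that of compound 3. Going by these compounds, it is also open whether the same swap would cost as much with the chain of compound 1.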